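Trading the pyridinylamino of compound 3 for a small lactam

This account rests on a few compounds, and the source may have more. Where it says the series, first, only, none or still open, it means among the compounds named here.

In a physicochemical assay for solubility, read by LC-MS, in phosphate buffer, with a stated time of 24 h, at pH 7.4 (a lower number here means a less soluble compound, a higher number a more soluble compound), compound 3, `CN(c1cccnc1)c1cnc(NCc2c(F)ccc3c2CCO3)n2cnnc12`, stands highest of the two numbers recorded, its nearest neighbour being compound 2, `O=C1c2ccccc2CN1c1cnc(NCc2c(F)ccc3c2CCO3)n2cnnc12`, whose solubility is 4000 nM. Compound 3 itself gives 47000 nM. Compound 1, `O=C(Nc1ccccc1)c1cnc(NCc2c(F)ccc3c2CCO3)n2cnnc12`, returns only a limit in this assay, < 1000 nM, and that limit is noted as the limit of < 1000 nM in this assay, at which 1 of the 3 values shown sits.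

Compound 4, `C[C@@H]1CC(=O)N(c2cnc(NCc3c(F)ccc4c3CCO4)n3cnnc23)C1`, has not yet been measured in this assay. It differs from compound 3 in one place: 4-methyl-2-oxopyrrolidin-1-yl in place of methyl(pyridin-3-yl)amino on an aromatic carbon.

Two of the measured steps bear on this change. The step from compound 1 to compound 2 was an at least 4.0-fold higher number from compound 1 to compound 2 (0.60 log units; beyond the scatter), so a non-aromatic ring with one hetero atom entering at this position went with a higher number. The step of a 12-fold higher number from compound 2 to compound 3 (1.07 log units; beyond the scatter) was large, so removing the six-membered aromatic ring of carbon only and bringing in the pyridine ring went with a higher number still. Compound 4 keeps a five-membered non-aromatic lactam but drops the aromatic ring with one hetero atom, so a modest fall from compound 3 is expected, landing between the values of compound 2 and compound 3. The step from compound 3 to compound 4 is therefore estimated at a 2.4-fold lower number from compound 3 to compound 4 (0.37 log units; beyond the scatter). For compound 4 the expected solubility is 20000 nM, with a range of 5000 nM to 80000 nM.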

Compound 4, solubility: 130000 nM
The estimate for compound 4 lay 6.5-fold (0.81 log units) below the measured number; measured number outside the range, above it.
By their numbers in this assay, from the lowest: compound 2; then compound 3; then compound 4. At a limit, below all of these: compound 1.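

In this assay, an aromatic ring on this carbon proves unnecessary for the highest number in the series: 4-methyl-2-oxopyrrolidin-1-yl, which carries no aromatic ring, replaces methyl(pyridin-3-yl)amino and gives a further rise (a 2.8-fold higher number from compound 3 to compound 4 (0.44 log units; beyond the scatter)), so the pyridine ring of compound 3 is not what sets the upper end here. The comparison with the other lactam shows more: both compounds carry a five-membered non-aromatic ring with one hetero atom, yet the group without the six-membered aromatic ring of carbon only stands far higher (a 33-fold higher number from compound 2 to compound 4 (1.51 log units; beyond the scatter)), which places the large difference with the presence of that carbon-only aromatic ring rather than with the lactam as such. Compound 1 gives only a limit, so the step from its phenylcarbamoyl group is a bound and not an exact size (an at least 130-fold higher number from compound 1 to compound 4 (2.11 log units; beyond the scatter)), as the following states: the limit of < 1000 nM in this assay, at which 1 of the 4 values shown sits.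

The compounds shown leave open what the methyl group and the defined stereocentre of the lactam contribute, as neither the unsubstituted 2-oxopyrrolidin-1-yl nor the opposite stereoisomer appears among them. They also leave open how a morpholin-4-yl group or a carboxylic acid on this aromatic carbon would stand in this assay.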